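Ethoxy in Place of Fluoro on the Aryl Arm

The compounds below may be only part of what the source reports. "The series", "measured", "known", "first", "only" and "open" are said of these compounds alone.

Within the data shown here, compound 2 `OC[C@H]1OC(n2cnc3c(-c4ccc(F)cc4)ncnc32)[C@H](O)[C@@H]1O` gives 4500 nM in a functional assay on L1210 cells (Mus musculus) for inhibition (a lower number here means a stronger inhibitor, a higher number a weaker inhibitor), the lowest of the two numbers measured so far. Among the measured compounds shown here, compound 1 `OC[C@H]1OC(n2cnc3c(-c4ccc(F)c(F)c4)ncnc32)[C@H](O)[C@@H]1O` gives 20000 nM in this assay, and the only measured step, a 4.4-fold lower number from compound 1 to compound 2 (0.65 log units; beyond the scatter), removes a fluoro from an aromatic carbon. Compound 3 `CCOc1ccc(-c2ncnc3c2ncn3C2O[C@H](CO)[C@@H](O)[C@H]2O)cc1` differs from compound 2 by ethoxy in place of fluoro on an aromatic carbon, on an aromatic carbon of a six-membered aromatic ring of carbon only, para to a large group. For the measured compounds named here, no measured step exchanges a fluoro for an ethoxy; the single step that bears on the question shows only that altering the fluoro pattern on this ring moves this assay by a modest amount. A step of similar or smaller size is expected, with its direction open. Compound 3 is therefore estimated at 4000 nM, within a range from 900 nM to 18000 nM. This corresponds to an expected step of a 1.1-fold lower number from compound 2 to compound 3 (0.05 log units; within the scatter).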

Compound 3, half-maximal inhibitory concentration: 2500 nM
The estimate for compound 3 lay 1.6-fold (0.20 log units) above the measured number, and the stated range covers the measured number.
By their numbers in this assay, from the lowest: compounds 3 and 2 (each within the scatter of the next); then compound 1.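

Among these compounds, at this position, on an aromatic carbon para to a large group, the earlier compounds showed only changes in the fluoro pattern. Compound 3 now shows that ethoxy, with its 3 heavy atoms and 1 hydrogen-bond acceptor, can take the place of fluoro with only a 1.8-fold lower number from compound 2 to compound 3 (0.26 log units; within the scatter) in this assay, so the two groups cannot be told apart here. Set against the 3,4-difluorophenyl arm, the 4-ethoxyphenyl arm gives an 8.0-fold lower number from compound 1 to compound 3 (0.90 log units; beyond the scatter) in this assay, which places compound 3 with compound 2 on the lower side of compound 1.

Going by these compounds, whether a longer chain such as butoxy, an amine or a carboxylic acid would be accommodated at this position in the same way remains open. No measurement offered here accounts for the result.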